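Moving the methyl along the chain of a tetrazole leukotriene antagonist

This account rests on a few compounds, and the source may have more. Where it says the series, first, only, none or still open, it means among the compounds named here.

Measured compounds:
compound 1 `CC(CCc1cccc(OCc2ccc3ccccc3n2)c1)Cc1nnn[nH]1`: 17 nM
compound 2 `CC(CCC(=O)O)Cc1ccc(OCc2ccc3ccccc3n2)cc1`: 43 nM
compound 3 `O=C(O)CCCCc1ccc(OCc2ccc3ccccc3n2)cc1`: 110 nM

In an assay on membranes from lung (Cavia porcellus) for binding affinity to cysteinyl leukotriene receptor (Homo sapiens) (on this read-out higher numbers stand for weaker inhibition and lower numbers for stronger inhibition), compound 1 gives the lowest of the three numbers; compound 2 sits a step above it and compound 3 further still. Compound 4 `CC(CCc1nnn[nH]1)Cc1cccc(OCc2ccc3ccccc3n2)c1` keeps every atom of compound 1 but joins them differently: 3-(1H-tetrazol-5-yl)-1-methylpropyl in place of 2-((1H-tetrazol-5-yl)methyl)propyl on a saturated chain carbon bound to an aromatic carbon. Among the compounds with values here, no measured pair tests such a shift of the methyl along the chain. Within the data shown here, the only related step, a 2.6-fold higher number from compound 2 to compound 3 (0.41 log units; beyond the scatter), removes the methyl entirely from the acid series and is modest. A change of place rather than removal is therefore expected to give, at most, a small step in this assay, in either direction. Compound 4 is estimated at 25 nM (range 8 nM to 80 nM), a step of a 1.5-fold higher number from compound 1 to compound 4 (0.17 log units; within the scatter) that is expected to stay near the scatter.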

Compound 4, inhibition constant: 34 nM
The estimate for compound 4 lay 1.4-fold (0.13 log units) below the measured number; low and high end bracket the measured number.
By their numbers in this assay, from the lowest: compounds 1, 4 and 2 (each within the scatter of the next, the first and the last beyond it); then compound 3.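

In this assay, putting 3-(1H-tetrazol-5-yl)-1-methylpropyl in place of 2-((1H-tetrazol-5-yl)methyl)propyl gives a 2.0-fold higher number from compound 1 to compound 4 (0.30 log units; within the scatter). This pair gives the first direct test of moving the methyl along the tetrazole chain, and the two arrangements of the same atoms cannot be told apart on this read-out. Nothing available explains this result.

Still open, as far as these compounds go, is whether a carboxylic acid in place of the tetrazole, or a longer chain, on the core of compound 1 would keep binding at this level.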